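Moving Fluorine Around the Core of Compound 1

The compounds below may be only part of what the source reports. "The series", "measured", "known", "first", "only" and "open" are said of these compounds alone.

Compound 1 `O=c1c(-c2nn[nH]n2)c[nH]c2ccccc12` gives 1.25 mg/kg in a functional assay on the whole organism (strain Sprague-Dawley) for inhibition, with Rattus norvegicus as the target; a higher number here means that more compound is needed for the effect, a lower number that less compound is needed.
Compound 2 `O=c1c(-c2nn[nH]n2)c[nH]c2ccc(F)cc12` gives 1.25 mg/kg.
Compound 3 `COc1ccc2c(=O)c(-c3nn[nH]n3)c[nH]c2c1` gives 10 mg/kg.

Compound 1 stands level with compound 2 at the digits shown, and together they hold the lowest of the three numbers; the step of no change at the digits printed from compound 1 to compound 2 (within the scatter) and the step of an 8.0-fold higher number from compound 1 to compound 3 (0.90 log units; beyond the scatter) set the frame. Compound 4 `O=c1c(-c2nn[nH]n2)c[nH]c2c(F)cccc12` differs from compound 1 in one place: fluoro in place of hydrogen on an aromatic carbon. The step that bears most on it is no change at the digits printed from compound 1 to compound 2 (within the scatter), the same group entering at another place on the shared core, and it lay within the scatter. The larger step of an 8.0-fold higher number from compound 1 to compound 3 (0.90 log units; beyond the scatter) came from a different group and weighs less here. A step in this assay of no more than the scatter is therefore expected. For compound 4 the estimate is 1.5 mg/kg, in a range from 0.6 mg/kg to 4 mg/kg. The expected step is thus a 1.2-fold higher number from compound 1 to compound 4 (0.08 log units; within the scatter).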

Compound 4, minimum effective dose: 0.625 mg/kg
Compound 4: the middle estimate sits 2.4-fold (0.38 log units) above what was measured, and the stated range covers the measured number.
By their numbers in this assay, from the lowest: compounds 4, 1 and 2 (each within the scatter of the next); then compound 3.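

In this assay, fluoro on this aromatic carbon, ortho to a fused ring, gives a 2.0-fold lower number from compound 1 to compound 4 (0.30 log units; within the scatter), so hydrogen can give way to fluoro here without a step beyond the scatter. Together with no change at the digits printed from compound 1 to compound 2 (within the scatter), this makes two places on the shared core where this same change stays within the scatter. No measured evidence is available to explain this result.

As far as these compounds go, what a chloro group, an amine or a carboxylic acid would do on this same carbon stays open. So does the effect of fluoro at both places together.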